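The source may hold more compounds than are shown below. What is called first, only, known or untested is meant among the compounds shown, and "the series" means these compounds.

Of the compounds shown here, two have been measured in a functional assay on cells (T-cell, Mus musculus) for inhibition; on this read-out higher numbers stand for weaker inhibition and lower numbers for stronger inhibition. Compound 1 `Cc1cccc(NC(=O)Nc2ccc3c(c2)COC3=O)c1` gives 2260 nM. Compound 2 `O=C(Nc1ccc(F)cc1)C(=O)Nc1ccc2c(c1)COC2=O` gives 570 nM, the lowest of the two numbers; compound 1 stands at a higher value, beyond the scatter.

Compound 3 `COc1ccc(NC(=O)C(=O)Nc2ccc3c(c2)COC3=O)cc1` differs from compound 2 in one place: methoxy in place of fluoro on an aromatic carbon. Going by the values given here, no comparable step among the measured compounds tells how such a swap changes the read-out, so for the step from compound 2 to compound 3 only a change within the scatter is expected, a 1.1-fold higher number from compound 2 to compound 3 (0.06 log units; within the scatter). For compound 3 the estimated value is 650 nM, with a range from 250 nM to 1700 nM.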

Compound 3, half-maximal inhibitory concentration: 153000 nM
Compound 3: middle estimate off by 240-fold (2.37 log units), on the low side, and the stated range ends below it.
By their numbers in this assay, from the lowest: compound 2; then compound 1; then compound 3.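

Swapping fluoro for methoxy, para to a large group, gives a 270-fold higher number from compound 2 to compound 3 (2.43 log units; beyond the scatter) in this assay, so this position is highly sensitive to the group it carries. Exchanging one heavy atom for two is enough to move inhibition from the stronger end of these compounds to the weakest. No measured property of these compounds accounts for the size of this step.

On these data alone, whether the loss is specific to methoxy remains open. Chloro, hydroxyl or an amine at this position could show how narrow the requirement is.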